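Shortening the alkyl chain on a pyrazine amide series

The source may report more compounds than this note shows. Statements on the series, on what has been measured and on what is new or still open speak of the compounds shown alone.

Measured so far:
- compound 1, `CCCCNc1nccnc1C(=O)NCc1ccccc1`: > 100000 nM
- compound 2, `O=C(NCc1ccccc1)c1nccnc1Cl`: "not determined" (no result reported)
- compound 3, `CCCCCCCNc1nccnc1C(=O)NCc1ccccc1`: 100000 nM

These three compounds share one core and differ only in the group attached to the nitrogen on the aromatic ring. In an ADME assay on HEL cells (Homo sapiens) for cytotoxicity, read by microscopy, with a stated time of 6 days (a lower number here means that less compound is tolerated, a higher number that more compound is tolerated), compound 3 gives 100000 nM, which is the only actual number among the three entries shown. For compound 1 the result is a limit of the assay, not a number; this is the situation described by the limit of > 100000 nM in this assay, at which 1 of the 3 values shown sits. For compound 2 no result was reported.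

Within the data shown here, the one measured step that connects two numbers runs a number no higher from compound 1 to compound 3 (the limit leaves the size open). It consists of propyl in place of hydrogen on a saturated chain carbon, four bonds along the chain from a nitrogen on an aromatic ring, and the limit on compound 1 leaves its size open.

Compound 4, `CCCCCNc1nccnc1C(=O)NCc1ccccc1`, is still to be measured. It differs from compound 3 by hydrogen in place of ethyl on a saturated chain carbon, five bonds along the chain from a nitrogen on an aromatic ring. The chain in compound 4 sits between those of compound 1 and compound 3, and the step from compound 1 to compound 3 shows no movement beyond a limit, so in this assay no step beyond the scatter is expected; the expected step is no change at the digits printed from compound 3 to compound 4 (within the scatter). Compound 4 is therefore estimated at 100000 nM, with a range from 50000 nM to 200000 nM.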

Compound 4, minimum cytotoxic concentration: >= 100000 nM
Compound 4 gave a limit, no number (the forecaster's own chance of this, stated with the estimate: 50%); the middle value sits exactly at the limit.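

In this assay, taking away the ethyl at this place, five bonds along the chain from a nitrogen on an aromatic ring, gives a number no lower from compound 3 to compound 4 (the limit leaves the size open). Among these compounds, this is the first look at a shortening that starts from the one compound with an actual number, and it shows no sign that less compound is tolerated once the chain is cut back. The entry for compound 4 is a limit of the assay, not a number, and the comparison with compound 1 cannot be read, as both ends of that step are limits: the limit of >= 100000 nM in this assay, at which 1 of the 4 values shown sits.

Among the compounds shown here, compound 3 remains the only entry with a number among the compounds compared here, so how far the two shorter chains lie from it stays unknown. Whether a chain longer than that of compound 3, or a chain carrying an amine or a carboxylic acid, would bring the number down in this assay is left open.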